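From methoxy to 4-methylpiperazin-1-yl on a shared core

A few compounds are considered here, and "the series" means these few. Any claim that something is new, unique, unknown or untested is made for them only; others in the source may bear on it.

Compound 1 `CCc1ccc(NC(=O)C2CCN(C/C=C/c3ccccc3)CC2)cc1`: 11600 nM
Compound 2 `COc1ccc(NC(=O)C2CCN(C/C=C/c3ccccc3)CC2)cc1`: 58200 nM

In a functional assay on MGC-803 cells (Homo sapiens) for inhibition, read by MTT assay, with a stated time of 72 h (a higher number here means a weaker inhibitor, a lower number a stronger inhibitor), compound 2 gives 58200 nM, the higher of the two numbers and so the weaker result of the pair. Compound 3 `CN1CCN(c2ccc(NC(=O)C3CCN(C/C=C/c4ccccc4)CC3)cc2)CC1` has not yet been measured. It differs from compound 2 by one change: 4-methylpiperazin-1-yl in place of methoxy on an aromatic carbon. A 4-methylpiperazin-1-yl group stands in place of methoxy on an aromatic carbon, para to a large group.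

Among the compounds with values here, only one measured step bears on this carbon: a 5.0-fold higher number from compound 1 to compound 2 (0.70 log units; beyond the scatter). This modest step, beyond the scatter, replaces ethyl with methoxy. It shows that a change at this carbon can shift the number, but neither measured compound carries a ring there, so it guides the size of the next step only loosely. Within the data shown here, with compound 2 at 58200 nM, the higher of only two values, a move toward a lower number is expected, though with little certainty. The expected change, similar in size to the measured one, is a 3.9-fold lower number from compound 2 to compound 3 (0.59 log units; beyond the scatter). For compound 3 the estimated value is 15000 nM, with an expected range of 4000 nM to 60000 nM.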

Compound 3, half-maximal inhibitory concentration: 14000 nM
Compound 3: the middle estimate sits 1.1-fold (0.03 log units) above what was measured; low and high end bracket the measured number.
By their numbers in this assay, from the lowest: compounds 1 and 3 (each within the scatter of the next); then compound 2.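

In this assay, the result shows that this carbon can carry a six-membered non-aromatic ring with 2 hetero atoms, which neither ethyl nor methoxy provided: replacing methoxy with 4-methylpiperazin-1-yl gives a 4.2-fold lower number from compound 2 to compound 3 (0.62 log units; beyond the scatter) and thus reverses the loss seen on going from ethyl to methoxy. Compared directly with ethyl, the same group gives a 1.2-fold higher number from compound 1 to compound 3 (0.08 log units; within the scatter) and so cannot be told apart from it, which means that two groups with very different heavy-atom counts and ring content read alike here, while methoxy alone stands at the weaker end among these three compounds. Nothing available here explains why methoxy differs from the other two groups or why the ring-bearing group matches ethyl.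

The compounds shown leave open whether the result depends on the ring itself, on its second nitrogen or on its methyl group, a question that morpholin-4-yl, piperidin-1-yl or an unsubstituted piperazine ring at this carbon would address. They also leave open how a simple open-chain amine such as dimethylamino or a carboxylic acid would read at this carbon on the shared core.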